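This account rests on a few compounds, and the source may have more. Where it says the series, first, only, none or still open, it means among the compounds named here.

Measured so far:
compound 1 `Nc1nc(Cl)c2ncn(Cc3ccccc3CCl)c2n1`, 6030 nM
compound 2 `ClCc1ccc(Cn2cnc3c(Cl)nc(Cl)nc32)cc1`, 12600 nM

Compound 1 holds the lowest of the two numbers in a functional assay on MDA-MB-435 cells (Homo sapiens) for cytotoxicity, read by sulforhodamine B assay, with a stated time of 48 h; on this read-out lower numbers stand for stronger inhibition of growth and higher numbers for weaker inhibition of growth; compound 2 sits a step higher, beyond the usual scatter, though the two differ in more than one place. Compound 3 `ClCc1ccccc1Cn1cnc2c(Cl)nc(Cl)nc21` has not yet been measured. It differs from compound 1 by one change: chloro in place of amino on an aromatic carbon. Going by the values given here, no measured pair isolates this change, so compound 3 is expected to give a modestly higher number, a step of a 1.5-fold higher number from compound 1 to compound 3 (0.17 log units; within the scatter). For compound 3 the estimated value is 9000 nM, with a range from 4000 nM to 20000 nM.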

Compound 3, concentration for 50% growth inhibition: 1620 nM
Estimate against measurement, compound 3: 5.6-fold (0.74 log units) above, outside the stated range (below it).
By their numbers in this assay, from the lowest: compound 3; then compound 1; then compound 2.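

In this assay, chloro in place of amino on the aromatic carbon between two ring nitrogen atoms gives a 3.7-fold lower number from compound 1 to compound 3 (0.57 log units; beyond the scatter) and so lowers the number beyond the usual scatter. Going by these compounds alone, this pair is the first to isolate a change at this position, and it shows that the amino group is not required for growth inhibition on these cells. Nothing available explains the size or direction of this step. The compounds shown leave open how a methoxy group, a bromo group or a methylamino group on this carbon would compare with chloro.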